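Adding one methyl to the amine of compound 2

This account rests on a few compounds, and the source may have more. Where it says the series, first, only, none or still open, it means among the compounds named here.

Compound 1 `C=C(C)n1c(=O)n(Cc2nc3ccccc3n2CCC(C)C)c2ccccc21` gives 24600 nM
Compound 2 `CC(C)CCn1c(Cn2c(=O)n(C(C)C)c3ccccc32)nc2cc(CN)ccc21` gives 3920 nM

Of the compounds shown here, two have been measured so far in an ADME assay on HEp-2 cells (Homo sapiens) for cytotoxicity (a lower number here means that less compound is tolerated, a higher number that more compound is tolerated), and the read-out is the half-maximal cytotoxic concentration. Compound 2 has the lower of the two numbers at 3920 nM, while compound 1 stands at 24600 nM, a gap beyond the usual scatter. These two compounds differ in more than one place, so their gap cannot be tied to any single change.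

Compound 3 `CNCc1ccc2c(c1)nc(Cn1c(=O)n(C(C)C)c3ccccc31)n2CCC(C)C` is compound 2 with one alteration, methyl in place of hydrogen on an amine nitrogen. Within the data shown here, no measured pair shows this change, so the data offer no direct guide to its effect. The expectation therefore starts from compound 2 at 3920 nM and assumes no step beyond the scatter in this assay, in either direction. The estimated change is a 1.1-fold higher number from compound 2 to compound 3 (0.06 log units; within the scatter). For compound 3 the estimated value is 4500 nM, with an expected range from 2000 nM to 10000 nM.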

Compound 3, half-maximal cytotoxic concentration: 1480 nM
Compound 3: the middle estimate sits 3.0-fold (0.48 log units) above what was measured; the measured number lies below the stated range.
By their numbers in this assay, from the lowest: compound 3; then compound 2; then compound 1.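

In this assay the amine nitrogen turns out to be a place where even the smallest addition registers: the step is a 2.6-fold lower number from compound 2 to compound 3 (0.42 log units; beyond the scatter) and it lies beyond the usual scatter, so less of compound 3 is tolerated in these cells. Among these compounds, this is the only comparison so far that can be tied to one change. Compound 1 and compound 2 differ in more than one place, and here a single methyl in place of a hydrogen is all that separates the two structures. Among the compounds shown here, nothing measured so far explains why this methyl goes with the lower number.

On these data alone, a single step cannot show a trend, so it remains open whether a second methyl on the same nitrogen, or a longer chain such as ethyl or propyl, would move the number further, leave it alone or reverse it. Also open, as far as these compounds go, is how the number would respond if the amine gave way to a hydroxyl group or a carboxylic acid, and whether the same methyl would give a similar step on another core.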